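Quinoxalinone series: alkyl in place of hydrogen on ring nitrogen

A few compounds are considered here, and "the series" means these few. Any claim that something is new, unique, unknown or untested is made for them only; others in the source may bear on it.

Measured in an assay on cells for activation of Cystic fibrosis transmembrane conductance regulator (Homo sapiens), read by fluorescence, with a stated time of 10 min; on this read-out higher numbers stand for an effect only at larger amounts of compound and lower numbers for an effect already at smaller amounts:
compound 1, `O=c1c(-c2ccc(F)c([N+](=O)[O-])c2)nc2ccccc2n1Cc1ccccc1`: 690 nM
compound 2, `Cc1cc2nc(-c3cccc([N+](=O)[O-])c3)c(=O)n(Cc3ccccc3)c2cc1C`: > 10000 nM
compound 3, `O=c1[nH]c2ccccc2nc1-c1cccc([N+](=O)[O-])c1`: > 10000 nM (a limit of the assay)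

Compound 3 carries only a hydrogen on the aromatic nitrogen and gives in this assay a value that is a limit, > 10000 nM. It sits at the limit of > 10000 nM in this assay, at which 2 of the 3 values shown sit, so nothing more than that limit is known for it. Compound 2 also returns a limit, > 10000 nM. Going by the values given here, only compound 1, with a benzyl on that nitrogen, gives a number, 690 nM; compound 1 differs from compound 3 in more than one place, so no single step between these two compounds can be stated.

Compound 4, `CCn1c(=O)c(-c2cccc([N+](=O)[O-])c2)nc2ccccc21`, is not yet measured. It differs from compound 3 by ethyl in place of hydrogen on an aromatic nitrogen. Among the compounds with values here, no measured step of this kind exists in the set. The expectation is that an at least 2.5-fold lower number from compound 3 to compound 4 (0.39 log units; beyond the scatter) runs toward smaller concentrations, beyond the usual scatter, though probably not as far as compound 1 at 690 nM. Compound 4 is therefore expected near 4000 nM, between 800 nM and 15000 nM.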

Compound 4, half-maximal effective concentration: 65 nM
Compound 4: the middle estimate sits 62-fold (1.79 log units) above what was measured; the whole stated range lies above it.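

In this assay the aromatic nitrogen of the shared core now has a step that can be read for a single change: ethyl in place of hydrogen gives an at least 150-fold lower number from compound 3 to compound 4 (2.18 log units; beyond the scatter) with nothing else altered. This position therefore tolerates substitution and responds strongly to it, and the group on it need not contain a ring, as ethyl has none and compound 4 returns a measured number. The starting point of this step, for compound 3, is a limit of the assay and not a number, so the true size of the step stays unknown: the limit of > 10000 nM in this assay, at which 2 of the 4 values shown sit.

From the compounds shown here alone, whether methyl, a longer chain such as propyl, or a chain ending in an amine or a carboxylic acid would keep this gain remains open. Compound 1 and compound 2 each differ from compound 4 in more than one place, so steps comparing benzyl with ethyl cannot be read.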